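This account rests on a few compounds, and the source may have more. Where it says the series, first, only, none or still open, it means among the compounds named here.

Working notes on the series. In an assay on isolated protein (strain albino) for antagonist activity at Voltage-dependent L-type calcium channel subunit alpha-1C (Cavia porcellus) (a lower number here means a stronger inhibitor, a higher number a weaker inhibitor), compound 2 `CCOC(=O)C1=C(C)NC(C)=C(C(=O)OC(C)C)C1c1cnc(SC)n1Nc1ccccc1` gives 3.22 nM and stands within the scatter of compound 1 `COC(=O)C1=C(C)NC(C)=C(C(=O)OC(C)C)C1c1cnc(SC)n1Nc1ccccc1`, which gives 6.35 nM in this assay; the step of a 2.0-fold lower number from compound 1 to compound 2 (0.29 log units; within the scatter) does not separate them. Compound 3 `CSc1ncc(C2C(C(=O)OC(C)C)=C(C)NC(C)=C2C(=O)OC(C)(C)C)n1Nc1ccccc1` carries tert-butyl in place of ethyl on an oxygen next to a carbonyl group. Among the compounds with values here, the only measured step on this ester oxygen is a 2.0-fold lower number from compound 1 to compound 2 (0.29 log units; within the scatter), a change in the same direction of alkyl growth, and it stayed within the scatter. From that alone no step beyond the scatter is expected for compound 3, a 1.1-fold higher number from compound 2 to compound 3 (0.04 log units; within the scatter). Compound 3 is therefore estimated at 3.5 nM, within 1.2 nM to 11 nM.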

Compound 3, half-maximal inhibitory concentration: 68.2 nM
Compound 3: the middle estimate sits 19-fold (1.29 log units) below what was measured; the whole stated range lies below it.
By their numbers in this assay, from the lowest: compounds 2 and 1 (each within the scatter of the next); then compound 3.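

On this oxygen next to a carbonyl group, methyl and ethyl do not separate in this assay, yet tert-butyl in place of ethyl gives a 21-fold higher number from compound 2 to compound 3 (1.33 log units; beyond the scatter), and tert-butyl in place of methyl gives an 11-fold higher number from compound 1 to compound 3 (1.03 log units; beyond the scatter). The small step among the two shorter groups therefore did not carry over to tert-butyl, and this position is not indifferent to the alkyl group it bears. No measured evidence here accounts for this result. The compounds shown leave open whether a straight butyl chain on this oxygen would read like ethyl or like tert-butyl.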